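A few compounds are considered here, and "the series" means these few. Any claim that something is new, unique, unknown or untested is made for them only; others in the source may bear on it.

Compound 1 `CN(C)/N=C/c1ccc(C2=CC(=O)c3ccccc3C2=O)o1` gives 6500 nM in a functional assay on SF-268 cells (Homo sapiens) for cytotoxicity, with a stated time of 48 h; on this read-out lower numbers stand for stronger inhibition of growth and higher numbers for weaker inhibition of growth. Compound 2 `CN(C)/N=C/c1ccc(C2=C(Cl)C(=O)c3ccccc3C2=O)o1` gives 9300 nM; the step of a 1.4-fold higher number from compound 1 to compound 2 (0.16 log units; within the scatter) puts chloro in place of hydrogen on a double-bonded ring carbon. Compound 3 `CN(C)/N=C/c1ccc(-c2c(O)ccc(O)c2C=O)o1`, built on a different core, gives 38300 nM, the highest of the three numbers, separated from compound 2 and from compound 1 by gaps beyond the scatter. Compound 4 `O=Cc1ccc(-c2c(O)ccc(O)c2C=O)o1` differs from compound 3 by a group of 2 heavy atoms (1 carbon, 1 oxygen; no ring) in place of a group of 5 heavy atoms (3 carbon, 2 nitrogen; no ring), on an aromatic carbon. Among the compounds with values here, no measured step touches that change: the only step known, a 1.4-fold higher number from compound 1 to compound 2 (0.16 log units; within the scatter), concerns another core and another substituent, so it offers no guide. With nothing bearing on it, compound 4 is expected to stay close to compound 3. The step of a 1.0-fold lower number from compound 3 to compound 4 (0.00 log units; within the scatter) is expected not to exceed the scatter. Compound 4 is estimated at 38000 nM, with a range from 12000 nM to 120000 nM.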

Compound 4, concentration for 50% growth inhibition: 35800 nM
For compound 4 the middle estimate is 1.1-fold (0.03 log units) above the measured one; low and high end bracket the measured number.
By their numbers in this assay, from the lowest: compounds 1 and 2 (each within the scatter of the next); then compounds 4 and 3 (each within the scatter of the next).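

In this assay, putting formyl in place of the group of 5 heavy atoms, on the aromatic carbon next to the ring oxygen, gives a 1.1-fold lower number from compound 3 to compound 4 (0.03 log units; within the scatter). At this position on the core of compound 3, the read-out therefore does not separate the two groups, although formyl is the smaller and carries 1 hydrogen-bond acceptor rather than 2. No available evidence accounts for this result.

As far as these compounds go, it remains open whether an amine or a carboxylic acid at this position would also stay within the scatter. The compounds shown also leave open whether the same exchange on the core of compound 1 would give a similar result.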